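A few compounds are considered here, and "the series" means these few. Any claim that something is new, unique, unknown or untested is made for them only; others in the source may bear on it.

Three compounds share one core and differ only in a single group on an aromatic carbon. Compound 1 `C=C(OCC)c1ccc(Nc2cccc3c2C(=O)N(C2CCC(=O)NC2=O)C3=O)cc1` carries 1-ethoxyethenyl there, and in an assay on FRT-Jurkat cells for inhibition of nuclear factor NF-kappa-B complex (Homo sapiens), read by flow cytometry, with a stated time of 24 h, tested at 10 uM (a higher number here means more inhibition at the concentration tested (going by the name of the read-out), a lower number less inhibition), compound 1 gives 10%. Compound 2 `CCCCCc1ccc(Nc2cccc3c2C(=O)N(C2CCC(=O)NC2=O)C3=O)cc1` carries pentyl, and in this assay compound 2 gives 23%. Compound 3 `CC(=O)c1ccc(Nc2cccc3c2C(=O)N(C2CCC(=O)NC2=O)C3=O)cc1` carries acetyl, and in this assay compound 3 gives 2%, which places it at the low end, although compound 1 sits within the scatter of it and only compound 2 stands higher beyond the scatter. The steps of a number 13 percentage points higher from compound 1 to compound 2 (beyond the scatter) and a number 21 percentage points lower from compound 2 to compound 3 (beyond the scatter) set pentyl apart, whereas a number 8 percentage points lower from compound 1 to compound 3 (within the scatter). Compound 4 `O=C1CCC(N2C(=O)c3cccc(Nc4ccc(O)cc4)c3C2=O)C(=O)N1` has not yet been measured. The change is hydroxy in place of acetyl on an aromatic carbon. Among the measured compounds shown here, no measured step swaps acetyl for hydroxy, and the step from 1-ethoxyethenyl to acetyl, a number 8 percentage points lower from compound 1 to compound 3 (within the scatter), stayed within the scatter, so a step of a number 6 percentage points higher from compound 3 to compound 4 (within the scatter) within the scatter is expected. The estimate for compound 4 in this assay is 8%, expected between 0% and 25%.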

Compound 4, a percentage reported as inhibition, at one concentration (the size of the read-out at that concentration, not a potency): 4%
Compound 4: the middle estimate sits 4 percentage points above what was measured; low and high end bracket the measured number.
By their numbers in this assay, from the lowest: compounds 3, 4 and 1 (each within the scatter of the next); then compound 2.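

In this assay, hydroxy in place of acetyl gives a number 2 percentage points higher from compound 3 to compound 4 (within the scatter), so bringing in a hydrogen-bond donor and taking out a carbonyl at this position does not separate the two compounds. Hydroxy also stays close to 1-ethoxyethenyl, with a number 6 percentage points lower from compound 1 to compound 4 (within the scatter), while pentyl stays apart, with a number 19 percentage points lower from compound 2 to compound 4 (beyond the scatter). Across these four compounds, pentyl is therefore the only group on this aromatic carbon that stands clear of the others, and the acetyl, hydroxy and 1-ethoxyethenyl compounds cannot be told apart.

From the compounds shown here alone, whether a longer chain such as heptyl, a shorter one such as propyl, or an amine in the same place would match pentyl remains open. Nothing available explains what sets pentyl apart from the other three groups.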